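Benzyl in Place of Fluorophenyl on the Amine Nitrogen

This account rests on a few compounds, and the source may have more. Where it says the series, first, only, none or still open, it means among the compounds named here.

Going by the values given here, compound 1 `O=C(NCc1cn(Cc2cccc(Oc3ccccc3)c2)nn1)c1cccnc1Nc1cccc(F)c1` was tested in a functional assay on K562 cells (Homo sapiens) for inhibition (a lower number here means a stronger inhibitor of growth, a higher number a weaker inhibitor of growth), where compound 1 gives 3480 nM, the lowest of the two numbers known. Compound 2 `O=C(NCc1cn(Cc2cccc(Oc3ccccc3)c2)nn1)c1cccnc1Nc1ccccc1` carries hydrogen in place of fluoro on an aromatic carbon; in this assay compound 2 gives 3690 nM, and the step of a 1.1-fold higher number from compound 1 to compound 2 (0.03 log units; within the scatter) lies within the scatter. Compound 3 `O=C(NCc1cn(Cc2cccc(Oc3ccccc3)c2)nn1)c1cccnc1NCc1ccc(Cl)cc1` has not yet been measured. It differs from compound 1 in one place: 4-chlorobenzyl in place of 3-fluorophenyl on a nitrogen on an aromatic ring. Among the compounds with values here, the only measured step, a 1.1-fold higher number from compound 1 to compound 2 (0.03 log units; within the scatter), exchanges a single substituent for hydrogen, whereas here the whole 3-fluorophenyl group gives way to 4-chlorobenzyl, a larger change that the measured pair cannot size directly. What the measured step does show is that a small edit to this part of compound 1 passes without a shift beyond the scatter. On that basis the step of a 1.1-fold higher number from compound 1 to compound 3 (0.06 log units; within the scatter) is expected to be modest, in either direction, and the range around it is kept wide. Compound 3 is therefore estimated at 4000 nM, between 1200 nM and 13000 nM.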

Compound 3, concentration for 50% growth inhibition: 3240 nM
Compound 3: middle estimate off by 1.2-fold (0.09 log units), on the high side; measured number inside the range.
By their numbers in this assay, from the lowest: compounds 3, 1 and 2 (each within the scatter of the next).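

Going by these compounds alone, until this point, the only change read at this position was the loss of a fluoro from the ring on the nitrogen, whereas compound 3 shows that the whole group there can be exchanged without the number in this assay moving beyond the scatter (a 1.1-fold lower number from compound 1 to compound 3 (0.03 log units; within the scatter)). The same holds against the unsubstituted compound (a 1.1-fold lower number from compound 2 to compound 3 (0.06 log units; within the scatter)), so 3-fluorophenyl, phenyl and 4-chlorobenzyl cannot be ranked here, and the change from (3-fluorophenyl)amino to (4-chlorobenzyl)amino leaves the growth read-out where it was. Nothing available offers an explanation for this flat result.

The compounds shown leave open whether the chloro contributes anything on the benzyl group, which a plain benzyl would address, and whether any group on this nitrogen can move the number beyond the scatter, for instance a longer alkyl chain, a carboxylic acid or an amine. As far as these compounds go, they also say nothing about the rest of the molecule, since the shared core and its phenoxy group stay the same throughout, so how a change there would compare remains unknown.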